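Swapping nitro for methyl on the shared core

The source may report more compounds than this note shows. Statements on the series, on what has been measured and on what is new or still open speak of the compounds shown alone.

Of the compounds shown here, two of the same core have been tested in an ADME assay on Vero cells (Chlorocebus sabaeus) for cytotoxicity, read by neutral red uptake, tested at 1575 ug/mL; a lower number here means a stronger effect, a higher number a weaker effect of the compound at the concentration tested. Compound 1 `O=C1CSC(c2ccc(O)cc2)N1CCN1CCCCC1` carries a hydroxy group on its aromatic ring and gives 12% in this assay. Compound 2 `O=C1CSC(c2ccc([N+](=O)[O-])cc2)N1CCN1CCCCC1` carries a nitro group instead and gives 15%. Going by the values given here, the only step measured so far, a number 3 percentage points higher from compound 1 to compound 2 (within the scatter), is within the scatter, so the two numbers cannot be told apart, and compound 2 stands alongside compound 1 rather than anywhere distinct.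

Compound 3 `Cc1ccc(C2SCC(=O)N2CCN2CCCCC2)cc1` has not yet been measured. It differs from compound 2 as follows: methyl in place of nitro on an aromatic carbon. Among the compounds with values here, no measured step involves a methyl group, so the only guide is the nitro-for-hydroxy step, which left the read-out unchanged beyond the scatter. On that basis, the step from compound 2 to compound 3 is expected to be small, no change at the digits printed from compound 2 to compound 3 (within the scatter), with no clear direction. For compound 3 the expected result in this assay is therefore 15%, within a range from 5% to 30%.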

Compound 3, a percentage reported as activity, at one concentration (the size of the read-out at that concentration, not a potency): 13%
The estimate for compound 3 lay 2 percentage points above the measured number; low and high end bracket the measured number.
By their numbers in this assay, from the lowest: compounds 1, 3 and 2 (each within the scatter of the next).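

In this assay, the aromatic carbon para to a large group has now carried three different groups, and none of the exchanges separates the compounds: methyl in place of nitro gives a number 2 percentage points lower from compound 2 to compound 3 (within the scatter), and methyl in place of hydroxy gives a number 1 percentage points higher from compound 1 to compound 3 (within the scatter). Nitro carries hydrogen-bond acceptors and methyl carries none, yet this read-out does not tell the two compounds apart, so for these three groups, the identity of the group at this position makes no measurable difference. No measurement available here explains why the three compounds cannot be told apart.

From the compounds shown here alone, it remains open whether an amine, a carboxylic acid or a longer alkyl chain on this aromatic carbon would give a number beyond the scatter of these three. Also open, going by these compounds, is whether a change elsewhere on the shared core would move the read-out, and, since each number comes from a single concentration and gives the size of the read-out rather than a potency, how the three compounds would compare at lower concentrations.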